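This account rests on a few compounds, and the source may have more. Where it says the series, first, only, none or still open, it means among the compounds named here.

Measured so far:
compound 1 `COC(=O)C1=C(C)N=C(C)/C(=C(\O)OC)C1c1ccccc1N` — 39800 nM
compound 2 `COC(=O)C1=C(C)N=C(C)/C(=C(\O)OC)C1c1cc(OC)c(OC)cc1OC` — 1000000 nM
compound 3 `COC(=O)C1=C(C)N=C(C)/C(=C(\O)OC)C1c1cccc(OC(C)=O)c1` — 6030 nM

Of the compounds shown here, three sharing one core have been tested in a functional assay (muscle tissue) with Cavia porcellus as the target; a higher number here means that more compound is needed for the effect, a lower number that less compound is needed. Compound 1 stands second highest of the three numbers: compound 3 gives a clearly lower number, beyond the scatter, while compound 2 gives a far higher number, also beyond the scatter. The next compound, compound 4 `COC(=O)C1=C(C)N=C(C)/C(=C(\O)OC)C1c1ccc(Br)cc1`, differs from compound 1 in one place: 4-bromophenyl in place of 2-aminophenyl on a saturated ring carbon. Going by the values given here, no step between two measured compounds tells how such an exchange plays out here, so the expectation rests on the spread of the three numbers alone. A modest step towards a lower number in this assay is expected, a 2.0-fold lower number from compound 1 to compound 4 (0.30 log units; within the scatter), not far beyond the scatter. Compound 4 is therefore estimated at 20000 nM, within a range from 4000 nM to 100000 nM.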

Compound 4, half-maximal effective concentration: 540 nM
Compound 4: the middle estimate sits 37-fold (1.57 log units) above what was measured, and the stated range ends above it.
By their numbers in this assay, from the lowest: compound 4; then compound 3; then compound 1; then compound 2.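

In this assay, 4-bromophenyl in place of 2-aminophenyl on the saturated ring carbon gives a large change (a 74-fold lower number from compound 1 to compound 4 (1.87 log units; beyond the scatter)), so the result at this position depends strongly on which phenyl group sits there. The exchange alters both the substituent and its place on the phenyl ring, and this single step cannot tell which of the two matters. Nothing available accounts for the size of this step.

Open, from the compounds shown here alone, is how 4-aminophenyl and 2-bromophenyl would compare, since these would separate the substituent from its place. Also open, going by these compounds, is whether other groups at the 4-position of the phenyl ring, such as a carboxylic acid, would give a similar number.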